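Cyanophenyl to Cyclopropyl on a Shared Imidazole Core

The compounds below may be only part of what the source reports. "The series", "measured", "known", "first", "only" and "open" are said of these compounds alone.

Measured so far:
compound 1 `Cc1ccccc1Cc1cnc(CCc2ccc(-c3ccccc3C(=O)O)cc2)[nH]1` gives 9.3 nM
compound 2 `Cc1cccc(Cc2cnc(CCc3ccc(-c4ccccc4C(=O)O)cc3)[nH]2)c1` gives 75 nM
compound 3 `N#Cc1ccc(Cc2cnc(CCc3ccc(-c4ccccc4C(=O)O)cc3)[nH]2)cc1` gives 723 nM

All three were tested in an in vitro functional assay on cells for agonist activity at Bombesin receptor subtype-3 (Mus musculus), read by luminescence and calcium flux; a higher number here means that more compound is needed for the effect, a lower number that less compound is needed. Compound 3 gives the highest number of the three, so it needs the most compound for the effect; the nearest is compound 2, as the step of a 9.6-fold higher number from compound 2 to compound 3 (0.98 log units; beyond the scatter) shows, and the furthest is compound 1, as the step of a 78-fold higher number from compound 1 to compound 3 (1.89 log units; beyond the scatter) shows.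

Compound 4 `O=C(O)c1ccccc1-c1ccc(CCc2ncc(CC3CC3)[nH]2)cc1` differs from compound 3 in one place: cyclopropyl in place of 4-cyanophenyl on a saturated chain carbon bound to an aromatic carbon. Among the measured compounds shown here, none of the measured steps swaps an aromatic ring for a small saturated ring, so they do not bear directly on this change. What they do show is that the group on this chain carbon matters a great deal, with steps an 8.1-fold higher number from compound 1 to compound 2 (0.91 log units; beyond the scatter) and a 78-fold higher number from compound 1 to compound 3 (1.89 log units; beyond the scatter) both beyond the scatter. Because compound 3 already sits at 723 nM, the step of a 1.2-fold lower number from compound 3 to compound 4 (0.08 log units; within the scatter) is expected to be modest and of uncertain direction. Compound 4 is therefore estimated at 600 nM, in a range of 100 nM to 4000 nM.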

Compound 4, half-maximal effective concentration: 72 nM
For compound 4 the middle estimate is 8.3-fold (0.92 log units) above the measured one; measured number below the stated range.
By their numbers in this assay, from the lowest: compound 1; then compounds 4 and 2 (each within the scatter of the next); then compound 3.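

A ring of carbon with aromatic character is not required on this saturated chain carbon for a low number in these compounds: swapping 4-cyanophenyl for the much smaller cyclopropyl gives a 10-fold lower number from compound 3 to compound 4 (1.00 log units; beyond the scatter). Cyclopropyl also matches 3-methylphenyl, with a 1.0-fold lower number from compound 2 to compound 4 (0.02 log units; within the scatter), but it does not reach 2-methylphenyl, as a 7.7-fold higher number from compound 1 to compound 4 (0.89 log units; beyond the scatter) shows, so compound 1 keeps the lowest number of the four. Nothing available here explains why these groups differ.

The compounds shown leave open how the number responds to the size of a saturated group at this place, for example with a cyclobutyl or cyclohexyl ring. They also leave open whether a ring is needed at all, which an open chain such as isobutyl would test.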